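The compounds below may be only part of what the source reports. "The series", "measured", "known", "first", "only" and "open" are said of these compounds alone.

The measured compounds, with their values in an ADME assay on MDCK cells (Canis lupus familiaris) for cytotoxicity, read by microscopy, with a stated time of 48 h; a higher number here means that more compound is tolerated, a lower number that less compound is tolerated:
compound 1 `C[C@H]1[C@H](NCc2cncs2)C[C@H]2C[C@@H]1C2(C)C` gives > 100000 nM
compound 2 `Cc1ccc(CN[C@@H]2C[C@H]3C[C@@H]([C@H]2C)C3(C)C)s1` gives 780 nM
compound 3 `C[C@H]1[C@H](NCc2cc(Br)cs2)C[C@H]2C[C@@H]1C2(C)C` gives 6250 nM

The value of compound 1 is a limit of this assay, not a number (the limit of > 100000 nM in this assay, at which 1 of the 3 values shown sits). Of the two numbers that remain, compound 3 stands highest; its nearest neighbour is compound 2, and the step of an 8.0-fold higher number from compound 2 to compound 3 (0.90 log units; beyond the scatter) goes with 4-bromothiophen-2-yl in place of 5-methylthiophen-2-yl on a saturated chain carbon bound to an amine nitrogen.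

Compound 4 `C[C@H]1[C@H](NCc2cnccn2)C[C@H]2C[C@@H]1C2(C)C` has not yet been measured in this assay. It differs from compound 3 as follows: pyrazin-2-yl in place of 4-bromothiophen-2-yl on a saturated chain carbon bound to an amine nitrogen. For the measured compounds named here, the steps that bear on this change are those away from compound 1, where a five-membered ring with two hetero atoms gave way to a thiophene: an at least 120-fold lower number from compound 1 to compound 2 (2.10 log units; beyond the scatter) and an at least 16-fold lower number from compound 1 to compound 3 (1.20 log units; beyond the scatter), both large and both downward. The change from compound 3 to compound 4 runs the other way, from a thiophene to a six-membered ring with two hetero atoms, so a large upward step is expected, with a fair chance that only a limit is reported. Compound 4 is therefore estimated at 50000 nM, within 10000 nM to 200000 nM, which means an expected step of an 8.0-fold higher number from compound 3 to compound 4 (0.90 log units; beyond the scatter).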

Compound 4, minimum cytotoxic concentration: > 100000 nM
Compound 4 gave a limit, no number (the forecaster's own chance of this, stated with the estimate: 45%); middle value at least 2.0-fold (0.30 log units) from the limit.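

In this assay, replacing 4-bromothiophen-2-yl with pyrazin-2-yl on a saturated chain carbon bound to an amine nitrogen gives an at least 16-fold higher number from compound 3 to compound 4 (1.20 log units; beyond the scatter), and replacing 5-methylthiophen-2-yl with the same group gives an at least 120-fold higher number from compound 2 to compound 4 (2.10 log units; beyond the scatter). Until now, 1,3-thiazol-5-yl in compound 1 was the only group at this place to end at the limit, whereas compound 4 shows the same outcome for a six-membered aromatic ring with 2 hetero atoms, so among these four compounds both rings with two hetero atoms end there and both thiophenes give numbers. The step between compound 1 and compound 4 cannot be read, and the two readable steps give only minimum sizes, as the value of compound 4 is itself a limit: the limit of > 100000 nM in this assay, at which 2 of the 4 values shown sit.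

As far as these compounds go, how compound 1 and compound 4 compare therefore remains open, as neither gives a number. From the compounds shown here alone, it is also open whether a phenyl ring, a pyridin-2-yl ring or an unsubstituted thiophen-2-yl ring at this place would fall with the two thiophenes or with compound 1 and compound 4.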